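Trimming an Ethyl to a Methyl on a Weak Urea

The source may hold more compounds than are shown below. What is called first, only, known or untested is meant among the compounds shown, and "the series" means these compounds.

This account concerns two measured ureas and another that has not yet been tested. Compound 1 `CCc1ccc(NC(=O)N(Cc2ccc(OC)c(OC)c2)n2cnnc2)cc1` was examined in a functional assay on MCF7 cells (Homo sapiens) for cytotoxicity, read by MTT assay, with a stated time of 48 h; a higher number here means a weaker inhibitor, a lower number a stronger inhibitor. In this assay compound 1 gives only a limit, > 50000 nM, and not a number. That limit, (the limit of > 50000 nM in this assay, at which 1 of the 2 values shown sits), shows that compound 1 sits at the weak end of what was measured here. Among the compounds with values here, the other measured compound, compound 2 `N#Cc1ccc(CN(C(=O)Nc2cc(C(F)(F)F)cc(C(F)(F)F)c2)n2cnnc2)cc1`, gives 7220 nM in this assay, so of the two, compound 2 is the one that returns a number.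

Compound 3 `COc1ccc(CN(C(=O)Nc2ccc(C)cc2)n2cnnc2)cc1OC` has not been measured. It differs from compound 1 in one place: hydrogen in place of methyl on a saturated chain carbon bound to an aromatic carbon. The shared core and the two methoxy groups are unchanged.

Because compound 1 gives only the limit > 50000 nM, the step to compound 3 cannot be anchored to a number. Compound 3 is expected to change from compound 1 by a step that the limit leaves unreadable from compound 1 to compound 3, that is, no step beyond the usual scatter. Compound 3 is therefore expected to give about 60000 nM in this assay, somewhere between 20000 nM and 200000 nM, most likely again reported only as a limit.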

Compound 3, half-maximal inhibitory concentration: > 50000 nM
Compound 3 ended at the assay's limit; the forecaster's own chance of this, stated with the estimate: 70%; the middle value is on the limit's open side.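

No step can be read from compound 1 to compound 3 in this assay, because each of the two compounds gives only a limit and not a number: the limit of > 50000 nM in this assay, at which 2 of the 3 values shown sit.

The compounds shown leave open whether ethyl to methyl changes the read-out at all on a urea that returns a number rather than a limit.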